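Moving the Methoxy Group Around the Sulfonyl Aryl Ring

The source may report more compounds than this note shows. Statements on the series, on what has been measured and on what is new or still open speak of the compounds shown alone.

Of the compounds shown here, three built on one shared core have been measured in a functional assay on HeLa cells for antagonist activity at 5-hydroxytryptamine receptor 6 (Homo sapiens); on this read-out higher numbers stand for weaker inhibition and lower numbers for stronger inhibition. Compound 1 `CN1CCN(c2ccc3c(c2)c(S(=O)(=O)c2cccc4ccccc24)nn3Cc2ccccc2)CC1` gives 2 nM in this assay. Compound 2 `CN1CCN(c2ccc3[nH]nc(S(=O)(=O)c4ccccc4Cl)c3c2)CC1` gives 101 nM. Compound 3 `COc1cccc(S(=O)(=O)c2n[nH]c3ccc(N4CCN(C)CC4)cc23)c1` gives 57 nM. Among these three numbers compound 3 holds the second highest place; compound 2 sits nearest, within the scatter, while compound 1 sits far lower, beyond the scatter.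

Going by the values given here, only one measured step changes a single group, and it concerns the aryl ring on the sulfonyl sulfur: a 1.8-fold lower number from compound 2 to compound 3 (0.25 log units; within the scatter). Exchanging one aryl ring for another at that position therefore left the number essentially unchanged.

Compound 4 `COc1ccc(S(=O)(=O)c2n[nH]c3ccc(N4CCN(C)CC4)cc23)cc1` awaits measurement. It differs from compound 3 by 4-methoxyphenyl in place of 3-methoxyphenyl on a sulfonyl sulfur — 4-methoxyphenyl in place of 3-methoxyphenyl on a sulfonyl sulfur. Among the compounds with values here, since the one measured step at this same position stayed within the scatter, and the methoxy group is merely moved rather than replaced, no shift beyond the scatter is expected in this assay, in either direction. Compound 4 is expected to give about 60 nM in this assay, within a range from 20 nM to 180 nM. The expected step is a 1.1-fold higher number from compound 3 to compound 4 (0.02 log units; within the scatter).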

Compound 4, half-maximal inhibitory concentration: 544 nM
The estimate for compound 4 lay 9.1-fold (0.96 log units) below the measured number, outside the stated range (above it).
By their numbers in this assay, from the lowest: compound 1; then compounds 3 and 2 (each within the scatter of the next); then compound 4.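

In this assay, going by these compounds alone, the aryl ring on a sulfonyl sulfur proves more sensitive than the earlier compounds suggested: exchanging 3-methoxyphenyl for 4-methoxyphenyl, two groups with the same atoms and the same counts of donors and acceptors, gives a 9.5-fold higher number from compound 3 to compound 4 (0.98 log units; beyond the scatter). Within the data shown here, the earlier step at this position stayed within the scatter, so this is the first sign that the arrangement of a group on this ring, and not just its atoms, can change inhibition here. The change from 2-chlorophenyl to 4-methoxyphenyl points the same way, with a 5.4-fold higher number from compound 2 to compound 4 (0.73 log units; beyond the scatter), although nothing shown here explains why moving the methoxy group matters so much.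

The compounds shown leave open whether the loss belongs to methoxy itself or would also follow another group in its place, such as an amine or a carboxylic acid on the ring in place of the methoxy of 4-methoxyphenyl. Compound 1 differs from the others in more than one place, so these data also cannot say which of its differences goes with its much lower number.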